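Changing the Indole on a Sulfonyl Series

This account rests on a few compounds, and the source may have more. Where it says the series, first, only, none or still open, it means among the compounds named here.

- compound 1 `Cn1c(=O)c(S(=O)(=O)c2ccc(F)cc2)cc2cnc(Nc3ccc4[nH]ccc4c3)nc21` gives 300 nM in a functional assay on DU-145 cells (Homo sapiens) for inhibition, read by trypan blue exclusion, with a stated time of 72 h; a lower number here means a stronger inhibitor, a higher number a weaker inhibitor 
- compound 2 `Cn1c(=O)c(S(=O)(=O)Nc2ccc(F)cc2F)cc2cnc(Nc3ccc4[nH]ccc4c3)nc21` gives 5000 nM 
- compound 3 `Cn1c(=O)c(S(=O)(=O)c2ccc([N+](=O)[O-])cc2F)cc2cnc(Nc3ccc4[nH]ccc4c3)nc21` gives 400 nM 

Compound 1 stands at the low end of these numbers. The data show a 1.3-fold higher number from compound 1 to compound 3 (0.12 log units; within the scatter) and, much further off, a 17-fold higher number from compound 1 to compound 2 (1.22 log units; beyond the scatter). Compound 4 `Cn1c(=O)c(S(=O)(=O)c2ccc(F)cc2)cc2cnc(Nc3cnc4[nH]ccc4c3)nc21` keeps the 4-fluorophenyl on the sulfonyl sulfur of compound 1 and differs by one change, (a group of 9 heavy atoms (7 carbon, 2 nitrogen; one five-membered aromatic ring with 1 hetero atom, one six-membered aromatic ring with 1 hetero atom) in place of a group of 9 heavy atoms (8 carbon, 1 nitrogen; one five-membered aromatic ring with 1 hetero atom, one six-membered aromatic ring of carbon only), on a nitrogen on an aromatic ring). Going by the values given here, no measured step touches that place. All three steps lie at the sulfonyl sulfur, and the large ones, such as a 13-fold lower number from compound 2 to compound 3 (1.10 log units; beyond the scatter), say nothing direct about this swap. Among the compounds with values here, no large step can therefore be derived for this assay, and the direction stays open, with a slight lean towards a higher number and wide margins. The expected step is a 1.7-fold higher number from compound 1 to compound 4 (0.22 log units; within the scatter), which is not firmly beyond the scatter. For compound 4 the estimated value is 500 nM, with an expected range from 150 nM to 2000 nM.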

Compound 4, half-maximal inhibitory concentration: 500 nM
The estimate for compound 4 equals the measured number at the digits printed; low and high end bracket the measured number.
By their numbers in this assay, from the lowest: compounds 1, 3 and 4 (each within the scatter of the next); then compound 2.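

Of the steps shown, this is the only one away from the sulfonyl sulfur: on the nitrogen on an aromatic ring, this assay gives a 1.7-fold higher number from compound 1 to compound 4 (0.22 log units; within the scatter). The 1H-indol-5-yl group can therefore be replaced by the group with 7 carbon and 2 nitrogen, which carries 1 hydrogen-bond acceptor, with no step beyond the scatter when the 4-fluorophenyl stays on the sulfonyl sulfur. No evidence is available that bears on this result.

On these data alone, whether the same swap would give a similar step with the 2-fluoro-4-nitrophenyl of compound 3 or the (2,4-difluorophenyl)amino of compound 2 remains open. Also open, as far as these compounds go, is how a plain phenyl, or a phenyl carrying a morpholine or a carboxylic acid, would read at this nitrogen.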